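This account rests on a few compounds, and the source may have more. Where it says the series, first, only, none or still open, it means among the compounds named here.

In an ADME assay on CEMx174 cells (Homo sapiens) for cytotoxicity (a higher number here means that more compound is tolerated, a lower number that less compound is tolerated), compound 1 `CC1=C(C(=O)OCC2CCCCC2)C(c2ccccc2O)NC(=O)N1` gives > 10000 nM, which is a limit of the assay and not a number. Compound 2 `CCC1=C(C(=O)OCC2CCCCC2)C(c2ccc(O)cc2)NC(=O)N1` gives > 10000 nM, which is also a limit. Compound 2 thus stands at the limit of > 10000 nM in this assay, at which 2 of the 2 values shown sit, and no number places it more exactly. Compound 3 `CCC1=C(C(=O)OCC2CCCCC2)C(c2ccc(C(=O)OC)cc2)NC(=O)N1` has not yet been measured. It differs from compound 2 by methoxycarbonyl in place of hydroxy on an aromatic carbon, with methoxycarbonyl in place of hydroxy on an aromatic carbon, para to a large group. Going by the values given here, no measured step between compounds that differ in one place is available to guide the expectation. It rests instead on compound 2 and its limit of > 10000 nM, and no change beyond the scatter is expected in either direction. The estimated step is a step that the limit leaves unreadable from compound 2 to compound 3. For compound 3 the expected value is 12000 nM, with an estimated range of 4000 nM to 30000 nM.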

Compound 3, half-maximal cytotoxic concentration: > 10000 nM
Compound 3 gave a limit, no number; the forecaster's own chance of this, stated with the estimate: 85%; the middle value is on the limit's open side.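

Compound 2 and compound 3 both give a limit and not a number in this assay, so the step between them cannot be read. The compounds shown leave open whether any change to the shared core would yield a measurable value: the limit of > 10000 nM in this assay, at which 3 of the 3 values shown sit.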